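Two Dichlorophenyl Patterns Compared in the Writhing Test

The source may report more compounds than this note shows. Statements on the series, on what has been measured and on what is new or still open speak of the compounds shown alone.

The measured compounds:
compound 1, `COc1ccc(N2CCN(CCC(OC(N)=O)c3ccc(Cl)c(Cl)c3)CC2)cc1`, gives 61% in a functional assay on the whole organism for inhibition, with Mus musculus as the target, in the writhing test, with a stated time of 1 h, at a dose of 10 mg/kg by the oral route; on this read-out higher numbers stand for more inhibition at the one dose given (going by the name of the read-out) and lower numbers for less inhibition
compound 2, `NC(=O)OC(CCN1CCN(c2ccccc2O)CC1)c1ccccc1`, gives 37%
compound 3, `COc1ccc(N2CCN(CCC(OC(N)=O)c3ccc(Cl)c(C(F)(F)F)c3)CC2)cc1`, gives 46%

Compound 1 stands highest of the three numbers. Its nearest neighbour is compound 3, reached by a number 15 percentage points lower from compound 1 to compound 3 (beyond the scatter), a change of trifluoromethyl in place of chloro on an aromatic carbon. Among the measured compounds shown here, compound 2 lies furthest away; it differs from compound 1 in more than one place, so its two values show only that compound 2 sits well below compound 1 in this assay.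

The unmeasured compound 4, `COc1ccc(N2CCN(CCC(OC(N)=O)c3ccc(Cl)cc3Cl)CC2)cc1`, differs from compound 1 by 2,4-dichlorophenyl in place of 3,4-dichlorophenyl on a saturated chain carbon bound to an oxygen next to a carbonyl group and a saturated chain carbon. For the measured compounds named here, no measured pair shows this exact rearrangement. Going by the values given here, the only single-point step on the same aromatic ring, from compound 1 to compound 3, was a modest loss when the substitution on that ring was altered, and compound 2 shows that further departures from compound 1 also fall lower. On that basis a modest decrease beyond the scatter is expected for compound 4, with a number 13 percentage points lower from compound 1 to compound 4 (beyond the scatter) as the expected step. Compound 4 is therefore estimated at 48%, within a range from 33% to 63%.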

Compound 4, a percentage reported as inhibition, in the whole organism at one dose (the size of the read-out at that dose, not a potency): 16%
Estimate against measurement, compound 4: 32 percentage points above; the measured number lies below the stated range.
By their numbers in this assay, from the lowest: compound 4; then compounds 2 and 3 (each within the scatter of the next); then compound 1.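

The exchange of 3,4-dichlorophenyl for 2,4-dichlorophenyl, on a saturated chain carbon bound to an oxygen next to a carbonyl group and a saturated chain carbon, gives a number 45 percentage points lower from compound 1 to compound 4 (beyond the scatter) in this assay even though both groups hold the same heavy atoms and the same counts of hydrogen-bond donors and acceptors. The earlier step on this ring, a number 15 percentage points lower from compound 1 to compound 3 (beyond the scatter), replaced chloro with trifluoromethyl and so changed the atoms, whereas this one shows that the arrangement of the two chlorines alone can decide much of the read-out at this dose. No measurement shown here accounts for the size of this step.

From the compounds shown here alone, it remains open whether the loss belongs to the 2,4-dichlorophenyl pattern itself or would also appear with fluoro or nitrile in place of chloro on the ring. With only one dose shown, it is also open whether compound 4 would reach the level of compound 1 at higher doses, or whether the same exchange would cost as much on a core other than that of compound 1.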